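This account rests on a few compounds, and the source may have more. Where it says the series, first, only, none or still open, it means among the compounds named here.

Measured compounds in a functional assay on isolated protein for agonist activity at Glucose-dependent insulinotropic receptor (Homo sapiens), read by HTRF and cAMP accumulation; on this read-out lower numbers stand for an effect already at smaller amounts and higher numbers for an effect only at larger amounts of compound:

compound 1 `CC(C)(C)OC(=O)N1CCC(O[C@H]2CC[C@H](Oc3ccc(S(C)(=O)=O)cc3F)CC2)CC1`: 8.5 nM
compound 2 `CC(C)OC(=O)N1CCC(O[C@H]2CC[C@H](Oc3ccc(S(C)(=O)=O)nc3)CC2)CC1`: 13 nM
compound 3 `CC(C)OC(=O)N1CCC(O[C@H]2CC[C@H](Oc3cnc(S(C)(=O)=O)cn3)CC2)CC1`: 13.7 nM

Compound 3 has the highest of the three numbers, but its nearest neighbour is compound 2, and the step of a 1.1-fold higher number from compound 2 to compound 3 (0.02 log units; within the scatter) lies within the scatter, as does its gap to compound 1. Compound 4 `C[C@@H](CF)OC(=O)N1CCC(O[C@H]2CC[C@H](Oc3cnc(S(C)(=O)=O)cn3)CC2)CC1` differs from compound 3 by fluoro in place of hydrogen on a saturated chain carbon, two bonds along the chain from an oxygen next to a carbonyl group; the same difference, cut one bond further out, reads isopropyl to 1-(fluoromethyl)ethyl. For the measured compounds named here, the only measured step, that from compound 2 to compound 3, concerns the aromatic ring on the cyclohexyl oxygen and does not touch the carbamate chain. Compounds 1 and 2 differ in two places at once, so their values give no clean reading of the carbamate alone; what they show is two numbers within the scatter of each other. Going by the values given here, with no step bearing on the change, the expected step of a 1.1-fold lower number from compound 3 to compound 4 (0.06 log units; within the scatter) is none beyond the scatter. Compound 4 is therefore estimated at 12 nM in this assay, with a range from 4 nM to 35 nM.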

Compound 4, half-maximal effective concentration: 31.1 nM
Compound 4: middle estimate off by 2.6-fold (0.41 log units), on the low side; measured number inside the range.
By their numbers in this assay, from the lowest: compounds 1, 2 and 3 (each within the scatter of the next); then compound 4.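

In this assay the change from isopropyl to 1-(fluoromethyl)ethyl gives a 2.3-fold higher number from compound 3 to compound 4 (0.36 log units; beyond the scatter) and is the first single change shown to go beyond the scatter. For the compounds shown here, the only earlier step, a 1.1-fold higher number from compound 2 to compound 3 (0.02 log units; within the scatter) on the aromatic ring, did not, so this saturated chain carbon on the carbamate responds to a single fluoro in place of hydrogen, with the number moving upward. Nothing among the data given accounts for this shift.

The compounds shown leave open whether a hydroxyl or a methoxy at the same chain carbon would shift the number as fluoro does, and whether the mirror-image 1-(fluoromethyl)ethyl group would read the same. They also leave open whether the same change carries over to the compound with 6-(methylsulfonyl)pyridin-3-yl on the oxygen.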